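The source may hold more compounds than are shown below. What is called first, only, known or untested is meant among the compounds shown, and "the series" means these compounds.

Working notes on the sulfonyl ester series. Two compounds have been run in a functional assay on P815 cells (Mus musculus) for antiproliferative activity; a lower number here means a stronger inhibitor, a higher number a weaker inhibitor. Compound 1 `Cc1ccc(S(=O)(=O)O[C@@H]2[C@@H](O)[C@H](n3ccc(N)nc3=O)O[C@@H]2CO)cc1` gives 0.06 ug/mL. Compound 2 `CS(=O)(=O)O[C@@H]1[C@@H](O)[C@H](n2cc(F)c(N)nc2=O)O[C@@H]1CO` gives 0.02 ug/mL, the lower of the two numbers, and the gap to compound 1 lies beyond the scatter of this assay. Compounds 1 and 2 differ at more than one place, so no single step can be read from them. Compound 3 `Cc1ccc(S(=O)(=O)O[C@@H]2[C@@H](O)[C@H](n3cc(F)c(N)nc3=O)O[C@@H]2CO)cc1` is not yet measured; it keeps the core of compound 2 and differs only at the sulfonyl sulfur, where (4-methylphenyl in place of methyl on a sulfonyl sulfur). Compound 3 thus shares the 4-methylphenyl group on the sulfonyl sulfur with compound 1. Nothing in the measured pair isolates that change, so no large step is expected: the step from compound 2 to compound 3 is estimated at a 1.5-fold higher number from compound 2 to compound 3 (0.18 log units; within the scatter), within or close to the scatter. In this assay compound 3 is expected at 0.03 ug/mL, in the range 0.01 ug/mL to 0.1 ug/mL.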

Compound 3, concentration for 50% inhibition: 0.02 ug/mL
For compound 3 the middle estimate is 1.5-fold (0.18 log units) above the measured one; the measured number falls inside the stated range.
By their numbers in this assay, from the lowest: compounds 2 and 3 (each within the scatter of the next); then compound 1.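

In this assay, 4-methylphenyl in place of methyl on the sulfonyl sulfur gives no change at the digits printed from compound 2 to compound 3 (within the scatter), so on the core of compound 2 these two groups cannot be told apart at this position. Going by these compounds alone, with 4-methylphenyl held constant, fluoro in place of hydrogen on an aromatic carbon gives a 3.0-fold lower number from compound 1 to compound 3 (0.48 log units; beyond the scatter), the first reading of that change on its own and the only step here beyond the scatter. No supporting data bear on why either step has its size.

The compounds shown leave open whether a sulfonyl sulfur carrying a longer alkyl chain, an amine or a carboxylic acid-bearing phenyl group would read the same as methyl and 4-methylphenyl. They also leave open whether chloro on that aromatic carbon would match fluoro, and whether the fluoro step has the same size with methyl on the sulfonyl sulfur.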